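Sulfonyl aryl swap and human liver microsome clearance

The compounds below may be only part of what the source reports. "The series", "measured", "known", "first", "only" and "open" are said of these compounds alone.

Measured so far:
compound 1 `O=C(NCc1ccc(S(=O)(=O)c2cncc(C(F)(F)F)c2)cc1)N1Cc2ccncc2C1` — 13 mL/min/kg
compound 2 `O=C(NCc1ccc(S(=O)(=O)c2cc(F)cc(F)c2)cc1)N1Cc2ccncc2C1` — 8 mL/min/kg

In an ADME assay on microsomes from liver (Homo sapiens) for pharmacokinetics, read by LC-MS, with a stated time of 60 min, tested at 1 uM (a lower number here means slower removal, a higher number faster removal of the compound), compound 2 gives the lowest of the two numbers; its nearest neighbour is compound 1, with a 1.6-fold lower number from compound 1 to compound 2 (0.21 log units; within the scatter). Compound 3 `CCCn1cc(S(=O)(=O)c2ccc(CNC(=O)N3Cc4ccncc4C3)cc2)cn1` differs from compound 2 in one place: 1-propyl-1H-pyrazol-4-yl in place of 3,5-difluorophenyl on a sulfonyl sulfur. Among the compounds with values here, the only measured step, the exchange of the aryl group on the sulfonyl sulfur from compound 1 to compound 2, stayed within the scatter, and no measured step involves a pyrazole. Compound 3 is therefore expected to remain close to compound 2, with a step of a 1.5-fold higher number from compound 2 to compound 3 (0.18 log units; within the scatter). For compound 3 the estimate is 12 mL/min/kg, with a range of 5 mL/min/kg to 28 mL/min/kg.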

Compound 3, clearance: 11 mL/min/kg
Compound 3: middle estimate off by 1.1-fold (0.04 log units), on the high side; the measured number falls inside the stated range.
By their numbers in this assay, from the lowest: compounds 2, 3 and 1 (each within the scatter of the next).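

Within the data shown here, with 1-propyl-1H-pyrazol-4-yl on the sulfonyl sulfur, a five-membered aromatic ring joins the six-membered aromatic rings of the earlier compounds, and in this assay neither new step leaves the scatter: a 1.4-fold higher number from compound 2 to compound 3 (0.14 log units; within the scatter) and a 1.2-fold lower number from compound 1 to compound 3 (0.07 log units; within the scatter). The three groups at this place therefore stand within the scatter of one another, including the pair of hydrogen-bond acceptors that 1-propyl-1H-pyrazol-4-yl brings in place of none on 3,5-difluorophenyl. Nothing available bears on the reason for this result.

Still open, on these data alone, is whether any group on the sulfonyl sulfur gives a step beyond the scatter, for example a pyrazole carrying an amine or a carboxylic acid in place of the propyl chain.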